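The source may hold more compounds than are shown below. What is called first, only, known or untested is meant among the compounds shown, and "the series" means these compounds.

Values in a physicochemical assay for lipophilicity, using the shake flask method (on this read-out lower numbers stand for lower lipophilicity and higher numbers for higher lipophilicity), so far
- compound 1 `CC(C)Oc1cc(Oc2ccc(S(C)(=O)=O)cc2)cc(-c2cccc(=O)[nH]2)c1` gives 2.82
- compound 2 `CC(C)Oc1cc(Oc2ccc(S(C)(=O)=O)cc2)cc(-c2cncc(=O)[nH]2)c1` gives 2.27
- compound 3 `CC(C)Oc1cc(Oc2cnc(C(=O)N(C)C)nc2)cc(-c2nccc(=O)[nH]2)c1` gives 0.97

Compound 3 stands lowest of the three, with compound 2 nearest and compound 1 furthest. Compound 4 `C[C@@H](CO)Oc1cc(Oc2cnc(C(=O)N(C)C)nc2)cc(-c2nccc(=O)[nH]2)c1` differs from it in one place hydroxy in place of hydrogen on a saturated chain carbon, two bonds along the chain from an oxygen on an aromatic ring with hydroxy in place of hydrogen on a saturated chain carbon, turning isopropoxy into 1-(hydroxymethyl)ethoxy. Going by the values given here, no measured step makes this change. Among the compounds with values here, the only measured step, a number 0.55 log units lower from compound 1 to compound 2 (beyond the scatter) and modest in size, exchanges one aromatic ring for another, so it bears only loosely. From that step and the structural change, a downward step somewhat larger than it is expected in this assay for compound 4. The estimated step is a number 0.72 log units lower from compound 3 to compound 4 (beyond the scatter) in this expectation. Compound 4 is expected at 0.25 within an estimated range of -0.25 to 0.7 for this measurement.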

Compound 4, distribution coefficient: -0.02
Estimate against measurement, compound 4: 0.27 log units above; measured number inside the range.
By their numbers in this assay, from the lowest: compound 4; then compound 3; then compound 2; then compound 1.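

In this assay, the change from isopropoxy to 1-(hydroxymethyl)ethoxy gives a clear step (a number 0.99 log units lower from compound 3 to compound 4 (beyond the scatter)). Going by these compounds alone, this is the first reading at this chain, as the earlier step lay in an aromatic ring, and it shows that a single hydroxy on a saturated chain carbon moves the number beyond the usual scatter. Nothing available explains why the number moves. As far as these compounds go, it remains open whether an amine, a methoxy or a carboxylic acid on that carbon would move the number as far. From the compounds shown here alone, whether hydroxy gives a similar step on the core of compound 1 also remains open.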